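Replacing 3-Chlorophenyl in a Small Cytotoxicity Series

A few compounds are considered here, and "the series" means these few. Any claim that something is new, unique, unknown or untested is made for them only; others in the source may bear on it.

In a functional assay on U-937 cells (Homo sapiens) for cytotoxicity, read by MTT assay, with a stated time of 24 h (a higher number here means a weaker inhibitor, a lower number a stronger inhibitor), compound 2 (`Nc1nn(Cc2cn(-c3cccc(Cl)c3)nn2)c2nc(-c3ccccc3)cc(C(F)(F)F)c12`) stands lowest of the three measured compounds at 32.4 ug/mL on this scale. Compound 1 (`Nc1nn(Cc2cn(CCC(F)(F)C(F)(F)C(F)(F)C(F)(F)C(F)(F)C(F)(F)F)nn2)c2nc(-c3ccccc3)cc(C(F)(F)F)c12`) gives 98.2 ug/mL and compound 3 (`Cc1c(Br)cccc1-n1cc(Cn2nc(N)c3c(C(F)(F)F)cc(-c4ccccc4)nc32)nn1`) gives 97.2 ug/mL so these two lie level with each other and both lie above compound 2.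

Compound 4 (`Nc1nn(Cc2cn(CC(=O)Nc3c(F)cccc3F)nn2)c2nc(-c3ccccc3)cc(C(F)(F)F)c12`) departs from compound 2 in one place: ((2,6-difluorophenyl)carbamoyl)methyl in place of 3-chlorophenyl on an aromatic nitrogen and the group that enters still holds a six-membered aromatic ring of carbon only.

Among the compounds with values here, one measured step bears directly on this change: a 3.0-fold higher number from compound 2 to compound 3 (0.48 log units; beyond the scatter) when 3-bromo-2-methylphenyl takes the place of 3-chlorophenyl on that nitrogen. This step is modest but beyond the scatter. Compound 1 at 98.2 ug/mL adds a second case, with a fluorinated chain on the same nitrogen, and it also reads higher than compound 2. Two cases are thin support, and neither carries the amide of the new group, so a rise of similar or slightly smaller size is expected. The estimated move is a 2.2-fold higher number from compound 2 to compound 4 (0.33 log units; beyond the scatter) in this assay and it points toward a weaker inhibitor. Compound 4 is estimated at 70 ug/mL with 28 ug/mL and 170 ug/mL as the expected ends of its range.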

Compound 4, half-maximal inhibitory concentration: 30.6 ug/mL
Estimate against measurement, compound 4: 2.3-fold (0.36 log units) above; measured number inside the range.
By their numbers in this assay, from the lowest: compounds 4 and 2 (each within the scatter of the next); then compounds 3 and 1 (each within the scatter of the next).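

In this assay, moving from 3-chlorophenyl to ((2,6-difluorophenyl)carbamoyl)methyl on the aromatic nitrogen gives a 1.1-fold lower number from compound 2 to compound 4 (0.02 log units; within the scatter), so a replacement at this position need not come with the higher number seen for compound 3, even though the entering group is larger and brings one hydrogen-bond donor and one hydrogen-bond acceptor. The comparison with the other aryl-bearing compound gives a 3.2-fold lower number from compound 3 to compound 4 (0.50 log units; beyond the scatter), which shows that a six-membered aromatic ring of carbon only, present in both groups, does not by itself set the reading at this position. Nothing available here accounts for these readings.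

The compounds shown leave open whether the level reading of compound 4 with compound 2 depends on the amide link or on the two fluorines of the ring, a question that a plain phenylcarbamoylmethyl group on the same nitrogen would address. They also leave open how this position responds to groups of another kind, such as a carboxylic acid or a primary amine at the end of a short chain.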